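A Fluorine Added to the Outer Phenyl Ring

This account rests on a few compounds, and the source may have more. Where it says the series, first, only, none or still open, it means among the compounds named here.

Of the compounds shown here, two sharing the same core have been tested in a functional assay on Jurkat cells (Homo sapiens) for activation, with a stated time of 24 h; a higher number here means that more compound is needed for the effect, a lower number that less compound is needed. Compound 1 `Oc1ccccc1CNc1ccc(N2CCCCC2)cc1` carries a piperidine ring on the aniline side, and in this assay compound 1 is recorded as "not active" (no number reported), so no number is available for it. Compound 2 `Oc1ccccc1CNc1ccc(-c2ccccc2)cc1` carries a phenyl ring in the same position instead, and in this assay compound 2 gives 1820 nM. Among the entries shown, compound 2 therefore stands as the only compound with a numerical result; the other entry gives no figure to compare against.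

Compound 3 `Oc1ccccc1CNc1ccc(-c2ccc(F)cc2)cc1` differs from compound 2 in one place: fluoro in place of hydrogen on an aromatic carbon, which reads as fluoro in place of hydrogen on an aromatic carbon, or, one bond further out, phenyl to 4-fluorophenyl. For the measured compounds named here, no measured pair shows what such a change does here, so the expected step from compound 2 to compound 3 is small and may well lie within the ordinary scatter of this assay; any direction is possible, with a slight lean toward a lower number. For compound 3 the estimate in this assay is 1500 nM, expected to fall between 500 nM and 5000 nM, corresponding to an expected step of a 1.2-fold lower number from compound 2 to compound 3 (0.08 log units; within the scatter).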

Compound 3, half-maximal effective concentration: 3860 nM
Compound 3: middle estimate off by 2.6-fold (0.41 log units), on the low side; the measured number falls inside the stated range.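

In this assay, fluoro in place of hydrogen on an aromatic carbon, para to a large group, goes with a 2.1-fold higher number from compound 2 to compound 3 (0.33 log units; beyond the scatter), so more compound is needed for the effect once the fluoro is present. For the compounds shown here, this is the first measured step at this position, and it shows that the position responds to the addition of a single fluorine atom, although the step is only modest and rests on one pair of compounds. Nothing measured alongside these compounds bears on what lies behind the step.

The compounds shown leave open whether this higher number is particular to fluoro or would also appear with another group on the same carbon, such as chloro, methoxy, an amine or a carboxylic acid. A series of such groups would show whether the number keeps rising with each replacement of hydrogen or whether some group brings it down instead, which a single pair cannot reveal.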